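A few compounds are considered here, and "the series" means these few. Any claim that something is new, unique, unknown or untested is made for them only; others in the source may bear on it.

Compound 1 `Nc1nc(NC2CC2)c2ncn(/C=C3/CC3(CO)CO)c2n1` in an ADME assay on MOLT-3 cells (Homo sapiens) for cytotoxicity, with a stated time of 7 days (a higher number here means that more compound is tolerated, a lower number that less compound is tolerated), gives > 20000 nM, a limit of the assay.
Compound 2 `CCCNc1nc(N)nc2c1ncn2/C=C1/CC1(CO)CO` in this assay has "not determined" (no result reported).
Compound 3 `CCCCNc1nc(N)nc2c1ncn2/C=C1/CC1(CO)CO` in this assay gives > 20000 nM, again a limit.

Compound 2 thus stands without any number in this assay; the two further values around it are both limits, sitting at the limit of > 20000 nM in this assay, at which 2 of the 3 values shown sit. The move to compound 4 `Nc1nc(OCC(F)(F)F)c2ncn(/C=C3/CC3(CO)CO)c2n1` is 2,2,2-trifluoroethoxy in place of propylamino on an aromatic carbon. Among the compounds with values here, the only measured step, a step that the two limits leave unreadable from compound 1 to compound 3, cannot be read, so it gives no size and no direction for the change to compound 4. With both measured neighbours at the limit (the limit of > 20000 nM in this assay, at which 2 of the 3 values shown sit), no step beyond the scatter can be expected, and another limit is the most likely outcome. Compound 4 is therefore estimated at 30000 nM, expected within 8000 nM to 100000 nM.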

Compound 4, half-maximal cytotoxic concentration: > 20000 nM
Compound 4: a limit, no number; the forecaster's own chance of this, stated with the estimate: 85%; the middle value lies beyond the limit too.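

The steps from compound 1 and from compound 3 to compound 4 cannot be read, since all three compounds stand at one limit: the limit of > 20000 nM in this assay, at which 3 of the 4 values shown sit.

The compounds shown leave open whether any of these groups on the shared core changes the read-out in this assay at all.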